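The source may hold more compounds than are shown below. What is called first, only, known or untested is meant among the compounds shown, and "the series" means these compounds.

Compound 1 `O=C(CN1CCN(c2ccc([N+](=O)[O-])cc2)CC1)C(O)(c1ccccc1)C1CCC1` is one of the two entries measured so far. In a functional assay on ileum for antagonist activity at muscarinic acetylcholine receptor M3 (Cavia porcellus) (a lower number here means a stronger inhibitor, a higher number a weaker inhibitor), compound 1 gives only a limit, > 10000 nM. Compound 2 `CCOC(=O)N1CCN(CC(=O)C(O)(c2ccccc2)C2CCCCC2)CC1` likewise stops at a limit, compound 2 giving > 10000 nM in this assay. Compound 1 thus stands at the edge of what the measurement reports, and the limit of > 10000 nM in this assay, at which 2 of the 2 values shown sit, leaves no spread of numbers to read. Compound 3 `CC(C)=CCN1CCN(CC(=O)C(O)(c2ccccc2)C2CCC2)CC1` differs from compound 1 by 3-methylbut-2-en-1-yl in place of 4-nitrophenyl on an amine nitrogen in a ring. For the measured compounds named here, no measured step covers this change; a gain beyond the scatter is expected, probably a modest one. Compound 3 is estimated at 3000 nM in this assay, between 500 nM and 15000 nM. That amounts to an expected step of an at least 3.3-fold lower number from compound 1 to compound 3 (0.52 log units; beyond the scatter).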

Compound 3, antagonist equilibrium constant: 22 nM
Compound 3: middle estimate off by 140-fold (2.13 log units), on the high side; measured number outside the range, below it.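

Putting 3-methylbut-2-en-1-yl in place of 4-nitrophenyl on the amine nitrogen in the ring gives an at least 450-fold lower number from compound 1 to compound 3 (2.65 log units; beyond the scatter), so the group at this position can decide whether this assay returns a number at all. Compound 1 gives > 10000 nM, which is a limit. Compound 3 alone has a number so far, and the other compounds stop at: the limit of > 10000 nM in this assay, at which 2 of the 3 values shown sit.

On these data alone, whether a saturated 3-methylbutyl chain or a benzyl group at this nitrogen would keep the gain remains open. A single number supports no trend across the series.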